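This account rests on a few compounds, and the source may have more. Where it says the series, first, only, none or still open, it means among the compounds named here.

Compound 3, with the structure `CCN(CC)c1ccc2cc(C(=O)c3ccc(N4CCN(C(=O)CN5CCN(S(=O)(=O)c6ccc(F)cc6)CC5)CC4)cc3)oc2c1`, gives the weakest result among the three compounds measured in a functional assay on A549 cells (Homo sapiens) for cytotoxicity, read by MTT assay, with a stated time of 48 h (on this read-out lower numbers stand for stronger inhibition and higher numbers for weaker inhibition), where compound 3 gives 33200 nM. The nearest measured neighbour is compound 2, structure `CCN(CC)c1ccc2cc(C(=O)c3ccc(N4CCN(C(=O)CN5CCN(C(=O)CCl)CC5)CC4)cc3)oc2c1`, which in this assay gives 3060 nM, and the step of an 11-fold higher number from compound 2 to compound 3 (1.04 log units; beyond the scatter) separates them. Compound 1, structure `CCN(CC)c1ccc2cc(C(=O)c3ccc(N4CCN(C(=O)CN5CCNCC5)CC4)cc3)oc2c1`, gives 320 nM and is furthest away, with the step of a 100-fold higher number from compound 1 to compound 3 (2.02 log units; beyond the scatter). Compound 1 carries a hydrogen on the ring nitrogen where compounds 2 and 3 carry a group, and the step of a 9.6-fold higher number from compound 1 to compound 2 (0.98 log units; beyond the scatter) shows that adding the (chloromethyl)carbonyl there already raised the number.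

Compound 4, structure `CCN(CC)c1ccc2cc(C(=O)c3ccc(N4CCN(C(=O)CN5CCN(Cc6ccc(F)c(F)c6)CC5)CC4)cc3)oc2c1`, is a new variation at the same position: 3,4-difluorobenzyl in place of (4-fluorophenyl)sulfonyl on an amine nitrogen in a ring. Both steps from compound 1 show that putting a group on that ring nitrogen raised the number, and the step from compound 2 to compound 3 shows that the (4-fluorophenyl)sulfonyl gave the weakest result of all. Going by the values given here, replacing it with a 3,4-difluorobenzyl is therefore expected to move the number back down, but no measured compound carries a benzyl here, so the size is uncertain. The estimated step is a 9.5-fold lower number from compound 3 to compound 4 (0.98 log units; beyond the scatter), and compound 4 is expected to give about 3500 nM, within a range from 900 nM to 14000 nM.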

Compound 4, half-maximal inhibitory concentration: 5440 nM
The estimate for compound 4 lay 1.6-fold (0.19 log units) below the measured number; the range from low to high includes it.
By their numbers in this assay, from the lowest: compound 1; then compounds 2 and 4 (each within the scatter of the next); then compound 3.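

In this assay the 3,4-difluorobenzyl gives a 6.1-fold lower number from compound 3 to compound 4 (0.79 log units; beyond the scatter) even though it and the (4-fluorophenyl)sulfonyl each hold one six-membered aromatic ring of carbon only, so that ring alone does not set the number at this ring nitrogen. The 3,4-difluorobenzyl and the (chloromethyl)carbonyl are very different groups, yet they cannot be told apart here (a 1.8-fold higher number from compound 2 to compound 4 (0.25 log units; within the scatter)). The hydrogen still gives the lowest number, with a 17-fold higher number from compound 1 to compound 4 (1.23 log units; beyond the scatter), so all three groups shown on this nitrogen give a higher number than the hydrogen does.

Nothing available explains these differences. Also open, from the compounds shown here alone, is whether a methyl or a longer chain ending in an amine on this nitrogen would stay as close to compound 1 as the hydrogen's low number suggests is possible.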